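Swapping Thiophene for Phenyl on a Nucleoside Core

A few compounds are considered here, and "the series" means these few. Any claim that something is new, unique, unknown or untested is made for them only; others in the source may bear on it.

Of the compounds shown here, two have so far been tested in a functional assay on K562 cells (Homo sapiens), read by MTT assay, with a stated time of 72 h; on this read-out lower numbers stand for stronger inhibition and higher numbers for weaker inhibition. Among the compounds with values here, compound 1 `C#Cc1cn([C@@H]2O[C@H](CO)[C@@H](O)[C@H]2O)c2ncnc(C)c12` is the only one with a definite number: in this assay compound 1 gives 110 nM. Compound 2 `O=c1[nH]cnc2c1c(-c1ccsc1)cn2[C@@H]1O[C@H](CO)[C@@H](O)[C@H]1O` carries a thiophen-3-yl group on the shared core and a different arrangement at the top of that core. For compound 2 this assay reports no number but only a limit, > 20000 nM. Compound 2 therefore sits at the limit of > 20000 nM in this assay, at which 1 of the 2 values shown sits, while compound 1 reaches a measurable value; nothing more than that can be read from these two values, since they differ in more than one place.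

Compound 3 `O=c1[nH]cnc2c1c(-c1ccccc1)cn2[C@@H]1O[C@H](CO)[C@@H](O)[C@H]1O` differs from compound 2 in a single place: phenyl in place of thiophen-3-yl on an aromatic carbon. Within the data shown here, no measured pair here shows what such an exchange does, so the expectation rests on compound 2 alone: a step of no direction beyond the usual scatter is expected, a step that the limit leaves unreadable from compound 2 to compound 3. Compound 3 is thus expected to give about 25000 nM, somewhere between 8000 nM and 80000 nM, and most likely this assay will again report only a limit for compound 3.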

Compound 3, half-maximal inhibitory concentration: > 20000 nM
Compound 3 ended at the assay's limit (the forecaster's own chance of this, stated with the estimate: 75%); the middle value lies beyond the limit too.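

Compound 2 and compound 3 each give only a limit and no number, so the exchange of thiophen-3-yl for phenyl yields no step that can be read between them: the limit of > 20000 nM in this assay, at which 2 of the 3 values shown sit.

The compounds shown leave open whether this exchange changes anything in this assay, and what real value either compound would give.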